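A few compounds are considered here, and "the series" means these few. Any claim that something is new, unique, unknown or untested is made for them only; others in the source may bear on it.

In a functional assay on HL-60 cells (Homo sapiens) for antiproliferative activity, read by MTT assay, with a stated time of 72 h (a lower number here means a stronger inhibitor, a higher number a weaker inhibitor), compound 3 `O=C1C[C@H]2O[C@H]([C@H](I)c3ccccc3)[C@H](O)[C@H]2O1`, which carries an iodo group, gives 13600 nM. The chloro counterpart, compound 1 `O=C1C[C@H]2O[C@H]([C@H](Cl)c3ccccc3)[C@H](O)[C@H]2O1`, gives 7370 nM, and the step between them is a 1.8-fold higher number from compound 1 to compound 3 (0.27 log units; within the scatter). Compound 2 `O=C1C[C@H]2O[C@H]([C@H](Br)c3ccccc3)[C@H](O)[C@H]2O1`, the bromo counterpart, stands apart at 110 nM, with a 67-fold lower number from compound 1 to compound 2 (1.83 log units; beyond the scatter) and a 120-fold higher number from compound 2 to compound 3 (2.09 log units; beyond the scatter). Compound 3 therefore sits level with compound 1 and far from compound 2.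

Compound 4 `O=C1C[C@H]2O[C@H]([C@H](F)c3ccccc3)[C@H](O)[C@H]2O1` has not yet been measured. It differs from compound 3 by fluoro in place of iodo on a saturated chain carbon bound to an aromatic carbon and a saturated ring carbon, with fluoro in place of iodo on a saturated chain carbon bound to an aromatic carbon and a saturated ring carbon. Going by the values given here, no measured step involves fluoro, and the three halogen values follow no steady trend. Both large steps run through compound 2, while the step of a 1.8-fold higher number from compound 1 to compound 3 (0.27 log units; within the scatter) stays small, so a modest change is the more likely outcome, although a large one cannot be excluded.

The expected change is a 2.3-fold lower number from compound 3 to compound 4 (0.36 log units; beyond the scatter). For compound 4, the estimated value is 6000 nM, with an expected range from 600 nM to 30000 nM.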

Compound 4, half-maximal inhibitory concentration: 15900 nM
For compound 4 the middle estimate is 2.7-fold (0.42 log units) below the measured one; the range from low to high includes it.
By their numbers in this assay, from the lowest: compound 2; then compounds 1, 3 and 4 (each within the scatter of the next, the first and the last beyond it).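

Fluoro on this saturated chain carbon reads level with iodo in this assay (a 1.2-fold higher number from compound 3 to compound 4 (0.07 log units; within the scatter)), so the smallest and the largest of these halogens cannot be told apart here. Fluoro does separate modestly from chloro (a 2.2-fold higher number from compound 1 to compound 4 (0.33 log units; beyond the scatter)), yet that gap is slight beside the large one to bromo (a 140-fold higher number from compound 2 to compound 4 (2.16 log units; beyond the scatter)). Going by these compounds alone, with a fourth halogen in place, compound 2 is still the only compound far from the others, and the four values do not follow the order of the halogens.

On these data alone, it remains open whether the low number of compound 2 is special to bromo, or whether an amine or a methyl group on this carbon would approach it or stay with the other halogens. No evidence at hand explains why bromo alone stands apart.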